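A few compounds are considered here, and "the series" means these few. Any claim that something is new, unique, unknown or untested is made for them only; others in the source may bear on it.

Working notes on the series. Compound 1 `Clc1ccc(Sc2c(-c3ccc(Cl)cc3)[nH]c3ccc(Cl)cc23)cc1` was tested in a functional assay on Hs 683 cells (Homo sapiens) for inhibition, read by MTT assay, with a stated time of 72 h (a higher number here means a weaker inhibitor of growth, a lower number a stronger inhibitor of growth), where compound 1 gives 31000 nM. Compound 2 `COc1ccc2[nH]c(-c3ccc(Cl)cc3)c(Oc3ccc(Cl)cc3)c2c1` carries a methoxy on the fused core in place of the chloro of compound 1 and an oxygen bridge to the chlorophenyl instead of sulfur; in this assay compound 2 gives 54000 nM. The two numbers sit within the scatter of each other, so compound 2 and compound 1 cannot be told apart on these data, and both are weak inhibitors of growth.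

Compound 3 `CCOC(=O)c1ccc2[nH]c(-c3ccc(Cl)cc3)c(Oc3ccc(Cl)cc3)c2c1` has not yet been measured. It differs from compound 2 by ethoxycarbonyl in place of methoxy on an aromatic carbon. Among the compounds with values here, no measured pair shows the effect of such a change, so the expectation rests only on the shared core of compound 2 and compound 3. The step from compound 2 to compound 3 is expected to be small, at most the size of the scatter, with no direction preferred: a 1.1-fold lower number from compound 2 to compound 3 (0.03 log units; within the scatter). Compound 3 is accordingly estimated at 50000 nM in this assay, with a range from 15000 nM to 150000 nM.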

Compound 3, concentration for 50% growth inhibition: 24000 nM
For compound 3 the middle estimate is 2.1-fold (0.32 log units) above the measured one; measured number inside the range.
By their numbers in this assay, from the lowest: compounds 3, 1 and 2 (each within the scatter of the next, the first and the last beyond it).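

In this assay, within the data shown here, ethoxycarbonyl in place of methoxy on this aromatic carbon, meta to a fused ring and para to a fused ring, gives a 2.3-fold lower number from compound 2 to compound 3 (0.35 log units; beyond the scatter) and is the first change that can be read at a single place. The position therefore accepts a group of five heavy atoms instead of two, with no loss of growth inhibition, although the modest step leaves compound 3 a weak inhibitor of growth. No measurement available here accounts for this step.

The compounds shown leave open whether the gain follows the carbonyl or the ethyl part of the group, which a carboxylic acid, a primary amide or a longer alkyl ester at this position would help to separate. Compound 1 differs from compound 2 in two places, so the sulfur and oxygen bridges also remain unseparated.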